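This account rests on a few compounds, and the source may have more. Where it says the series, first, only, none or still open, it means among the compounds named here.

Measured in a functional assay on cells (Platelet, Homo sapiens) for inhibition; on this read-out higher numbers stand for weaker inhibition and lower numbers for stronger inhibition:
- compound 1 (`CCOC(=O)c1ccc(-c2nn(Cc3cccc(F)c3)c3ccccc23)cc1`) gives 270 nM
- compound 2 (`CCOC(=O)c1ccc(-c2nn(Cc3ccc(F)cc3)c3ccccc23)cc1`) gives 190 nM
- compound 3 (`CCCOC(=O)c1ccc(-c2nn(Cc3ccccc3)c3ccccc23)cc1`) gives > 10000 nM as a limit of the assay

Compound 3 has no number on this scale. Its > 10000 nM is a limit and not a measured value, and it is the sole entry at the limit of > 10000 nM in this assay, at which 1 of the 3 values shown sits, in this set.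

Compound 4 (`CO/N=C\c1ccc(-c2nn(Cc3ccccc3)c3ccccc23)cc1`) is reached from compound 3 by one change, a group of 4 heavy atoms (2 carbon, 1 nitrogen, 1 oxygen; no ring) in place of a group of 6 heavy atoms (4 carbon, 2 oxygen; no ring), on an aromatic carbon on an aromatic carbon of a six-membered aromatic ring of carbon only. The propoxycarbonyl leaves, and a smaller group with no common name enters in the same place.

Among the measured compounds shown here, only one measured step exists, and it lies elsewhere in the molecule. In it, a 1.4-fold lower number from compound 1 to compound 2 (0.15 log units; within the scatter) follows from exchanging 3-fluorophenyl for 4-fluorophenyl, so it gives no size for the present change. For the measured compounds named here, no measured step links compound 3 to the other two. Still, compound 1 (270 nM) and compound 2 (190 nM) show that numbers on this scale do occur in this small set.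

The expected change in this assay is therefore an at least 6.6-fold lower number from compound 3 to compound 4 (0.82 log units; beyond the scatter) towards stronger inhibition, although another limit remains possible. For compound 4 the estimated value is 1500 nM within an expected range of 200 nM to 10000 nM on this thin evidence.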

Compound 4, half-maximal inhibitory concentration: > 10000 nM
Compound 4 gave a limit, no number; the forecaster's own chance of this, stated with the estimate: 35%; at least 6.6-fold (0.82 log units) between middle value and limit.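

In this assay compound 4 gives > 10000 nM as a limit of the assay and not a number. Compound 3 also stands at a limit, and no step can be read between compound 3 and compound 4. The limit is now shared: the limit of > 10000 nM in this assay, at which 2 of the 4 values shown sit. The compounds shown leave open whether exchanging the propoxycarbonyl for the smaller group changes inhibition at all.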